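A few compounds are considered here, and "the series" means these few. Any claim that something is new, unique, unknown or untested is made for them only; others in the source may bear on it.

Working notes on the series. Two compounds are in hand so far. Compound 1 `Nc1nc(N2CCCC2)sc1C(=O)/C=C/c1ccccc1` carries a pyrrolidin-1-yl group on the shared core; in a functional assay on MCF7 cells (Homo sapiens) for antiproliferative activity, read by MTT assay, with a stated time of 48 h (on this read-out higher numbers stand for weaker inhibition and lower numbers for stronger inhibition), compound 1 gives 21.7 ug/mL. Compound 2 `Nc1nc(N2CCCCC2)sc1C(=O)/C=C/c1ccccc1` carries a piperidin-1-yl group in its place; in this assay compound 2 gives 22.4 ug/mL. For the measured compounds named here, the single step measured, a 1.0-fold higher number from compound 1 to compound 2 (0.01 log units; within the scatter), shows that exchanging one saturated nitrogen ring for the other leaves the number essentially unchanged. On the numbers shown, compound 2 therefore stands level with compound 1, the gap between them lying within the scatter.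

The next compound, compound 3 `Nc1nc(N2CCCCC2)sc1C(=O)/C=C/c1ccc(Br)cc1`, differs from compound 2 by bromo in place of hydrogen on an aromatic carbon. Going by the values given here, no measured step touches this part of the molecule: the only step recorded concerns the saturated ring on the other side of the core and was itself within the scatter. No direction can be inferred for a change at the phenyl ring, so no step beyond the scatter is assumed, though the range is kept wide to reflect the lack of a bearing step. Compound 3 is estimated at 18 ug/mL in this assay, with a range of 7 ug/mL to 45 ug/mL, which corresponds to an expected step of a 1.2-fold lower number from compound 2 to compound 3 (0.09 log units; within the scatter).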

Compound 3, half-maximal inhibitory concentration: 25.6 ug/mL
Compound 3: middle estimate off by 1.4-fold (0.15 log units), on the low side; the range from low to high includes it.
By their numbers in this assay, from the lowest: compounds 1, 2 and 3 (each within the scatter of the next).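

For the compounds shown here, the change from phenyl to 4-bromophenyl is the first one made at this ring, and in this assay it gives a 1.1-fold higher number from compound 2 to compound 3 (0.06 log units; within the scatter), so one bromine atom entering on this aromatic carbon, para to a large group, leaves the number within the scatter. Read with a 1.0-fold higher number from compound 1 to compound 2 (0.01 log units; within the scatter), which concerns the saturated nitrogen ring, this means that a single change at either of two separate places has so far produced no step beyond the scatter, though each place rests on one step only. No measured evidence on hand bears on this result.

On these data alone, it remains open whether bromo is representative of this position, since an amine or a carboxylic acid in its place on the ring could give a step of a different size in this assay. Also unsettled is whether bromo would give a comparable step with pyrrolidin-1-yl on the shared core, as only the piperidin-1-yl compounds offer a reading of this change.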